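Removing the Pyrazole Ring: Expected Solubility of Compound 4

This account rests on a few compounds, and the source may have more. Where it says the series, first, only, none or still open, it means among the compounds named here.

Compound 1 `CNc1nc(NCCCN(C)C)c2sc(-c3ccc(-n4cccn4)cc3)cc2n1` gives 217 ug/mL in a physicochemical assay for solubility, at pH 2; a higher number here means a more soluble compound, a lower number a less soluble compound. Compound 2 `CNc1nc(NCCCN(C)C)c2sc(-c3ccc(C(F)(F)F)cc3)cc2n1` gives 240 ug/mL there, so the two sit within the scatter of each other, with a 1.1-fold higher number from compound 1 to compound 2 (0.04 log units; within the scatter). Compound 3 `CNc1nc(NCCCN(C)C)c2sc(-c3ccc(N4CCNCC4)cc3)cc2n1` reaches only a limit of the assay, > 100 ug/mL. Because of the limit of > 100 ug/mL in this assay, at which 1 of the 3 values shown sits, the steps from compound 1 and from compound 2 to compound 3 cannot be sized. Compound 4 `CNc1nc(NCCCN(C)C)c2sc(-c3ccccc3)cc2n1` differs from compound 1 by hydrogen in place of 1H-pyrazol-1-yl on an aromatic carbon. Among the measured compounds shown here, the one readable step that bears on this change, a 1.1-fold higher number from compound 1 to compound 2 (0.04 log units; within the scatter), also replaced the 1H-pyrazol-1-yl group and stayed within the scatter, so no step beyond the scatter is expected in this assay. Compound 4 is therefore expected at 200 ug/mL, between 80 ug/mL and 500 ug/mL, which means a 1.1-fold lower number from compound 1 to compound 4 (0.04 log units; within the scatter) as the estimated step.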

Compound 4, solubility: > 100 ug/mL
Compound 4 was reported as a limit (the forecaster's own chance of this, stated with the estimate: 15%); the middle value does not contradict the limit.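

No step linking compound 4 with compound 1, compound 2 or compound 3 can be read in this assay, and the reason is a limit: the limit of > 100 ug/mL in this assay, at which 2 of the 4 values shown sit.

The compounds shown leave open whether hydrogen in place of 1H-pyrazol-1-yl moves the number at all.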